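Hydroxy on the benzyl ring of a diaryl ether amine

A few compounds are considered here, and "the series" means these few. Any claim that something is new, unique, unknown or untested is made for them only; others in the source may bear on it.

Measured compounds:
Compound 1, `COc1cc(Oc2cccc(Nc3ccccc3)c2)cc(OC)c1CNCc1ccccc1`: 7490 nM
Compound 2, `COc1ccc(CCCNCc2c(OC)cc(Oc3cccc(Nc4ccccc4)c3)cc2OC)cc1`: 6400 nM
Compound 3, `COc1cc(Oc2cccc(Nc3ccccc3)c2)cc(OC)c1CCO`: > 20000 nM

In a functional assay on SW-620 cells (Homo sapiens) for inhibition, read by MTT assay, with a stated time of 72 h (on this read-out lower numbers stand for stronger inhibition and higher numbers for weaker inhibition), compound 1 gives 7490 nM and stands highest of the two plain numbers, though its nearest neighbour is close: a 1.2-fold lower number from compound 1 to compound 2 (0.07 log units; within the scatter). The value of compound 3 is a limit of this assay, not a number. Replacing the benzylamino chain by hydroxymethyl weakened inhibition, as an at least 2.6-fold higher number from compound 1 to compound 3 (0.42 log units; beyond the scatter) and an at least 3.1-fold higher number from compound 2 to compound 3 (0.49 log units; beyond the scatter) show, while the exchange in the first step, a 2-(4-methoxyphenyl)ethyl for phenyl, changed little.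

Compound 4, `COc1cc(Oc2cccc(Nc3ccccc3)c2)cc(OC)c1CNCc1ccc(O)cc1`, differs from compound 1 by hydroxy in place of hydrogen on an aromatic carbon. For the measured compounds named here, none of the measured steps alters this same aromatic carbon, so no step bears directly on it; the closest comparison, from compound 1 to compound 2, swapped the whole chain end and stayed within the scatter. The amine chain itself, which the larger steps show matters, is kept. The expected step is therefore a 1.1-fold lower number from compound 1 to compound 4 (0.03 log units; within the scatter), no change beyond the scatter. Compound 4 is estimated at 7000 nM, between 3000 nM and 16000 nM.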

Compound 4, half-maximal inhibitory concentration: 7940 nM
Beside the measured number, compound 4's estimate is 1.1-fold (0.05 log units) below it; the range from low to high includes it.
By their numbers in this assay, from the lowest: compounds 2, 1 and 4 (each within the scatter of the next). At a limit, above all of these: compound 3.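

In this assay, hydroxy in place of hydrogen on the phenyl ring of the benzylamino chain, para to a large group, brings no change beyond the scatter (a 1.1-fold higher number from compound 1 to compound 4 (0.03 log units; within the scatter)), and the comparison with the longer chain of compound 2 also stays within it (a 1.2-fold higher number from compound 2 to compound 4 (0.09 log units; within the scatter)). The new compound also confirms the importance of the amine chain, since (4-hydroxybenzyl)amino in place of hydroxymethyl gives a step beyond the scatter (an at least 2.5-fold lower number from compound 3 to compound 4 (0.40 log units; beyond the scatter)). The value of compound 3 is a limit, not a number: the limit of > 20000 nM in this assay, at which 1 of the 4 values shown sits.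

Hydroxy is the only group shown at this ring position, so it remains open whether a methoxy, an amine or a carboxylic acid there would shift the number. Also open, from the compounds shown here alone, is whether an amide in place of the amine would keep inhibition at this level.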